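A chlorinated pyridine in place of phenyl

The compounds below may be only part of what the source reports. "The series", "measured", "known", "first", "only" and "open" are said of these compounds alone.

Among the compounds with values here, compound 1 `c1ccc(NCc2ccc(CNc3ncccn3)cc2)cc1` is the only member of this set with a number: in a functional assay on the whole organism (strain C57BL/6L) for inhibition, with Mus musculus as the target, read by paw edema, with stated times of 30 min and 76 h, at a dose of 10 mg/kg by the intraperitoneal route (on this read-out lower numbers stand for less inhibition and higher numbers for more inhibition at the one dose given (going by the name of the read-out)), compound 1 gives 20%. Compound 2 `c1ccc(NCc2ccc(CNc3ccccn3)cc2)nc1` is reported in this assay only as "active" (no number reported), without a figure. Compound 3 `Clc1ccc(NCc2ccc(CNc3ncccn3)cc2)nc1` has not yet been tested. It differs from compound 1 in one place, (5-chloropyridin-2-yl in place of phenyl on an amine nitrogen). Within the data shown here, no measured pair shows what such a change does in this assay, so the step from compound 1 to compound 3 is expected to be small, a modest rise at most, and may well stay within the scatter: a number 10 percentage points higher from compound 1 to compound 3 (within the scatter). Compound 3 is therefore estimated to reach 30%, in the range 10% to 55%.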

Compound 3, a percentage reported as inhibition, in the whole organism at one dose (the size of the read-out at that dose, not a potency): 20%
Beside the measured number, compound 3's estimate is 10 percentage points above it; measured number inside the range.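

In this assay, 5-chloropyridin-2-yl in place of phenyl on an amine nitrogen gives no change at the digits printed from compound 1 to compound 3 (within the scatter). Within the data shown here, this is the first numerical comparison at this position, and it shows that the position accepts a ring with 1 hetero atom and a chlorine with no change beyond the scatter at the one dose given. No measurement bears on why the read-out stays level.

The compounds shown do not separate the contribution of the ring nitrogen from that of the chlorine. On these data alone, how a carboxylic acid or a morpholine on this amine nitrogen would read remains open.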